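Chain Homologation at the Hydroxyl-Bearing Carbon

The compounds below may be only part of what the source reports. "The series", "measured", "known", "first", "only" and "open" are said of these compounds alone.

Compound 1 `CCCCC(O)c1ccc(CN(CCCCCCC(=O)O)S(C)(=O)=O)cc1` — > 3200 nM
Compound 2 `CCCCc1ccc(CN(CCCOc2cccc(C(=O)O)c2)S(C)(=O)=O)cc1` — > 3200 nM
Compound 3 `CC(C)(C)c1ccc(CN(Cc2cccc(OCC(=O)O)c2)S(C)(=O)=O)cc1` — > 3200 nM

In an assay on HEK293 cells for inhibition of prostaglandin E2 receptor EP4 subtype (Rattus norvegicus) (on this read-out lower numbers stand for stronger inhibition and higher numbers for weaker inhibition), compound 1 gives only a limit of the assay, > 3200 nM. Compound 2 likewise gives only a limit, > 3200 nM. Compound 3 also gives only a limit, > 3200 nM. Among the compounds with values here, all three values rest at the limit of > 3200 nM in this assay, at which 3 of the 3 values shown sit, so no step between measured compounds can be read, and compound 1 cannot be placed relative to the others. Compound 4 `CCCCCC(O)c1ccc(CN(CCCCCCC(=O)O)S(C)(=O)=O)cc1` differs from compound 1 by methyl in place of hydrogen on a saturated chain carbon, five bonds along the chain from an aromatic carbon and an oxygen on a saturated carbon. Within the data shown here, no measured step bears on this change. Compound 1 sits at the limit of > 3200 nM in this assay, at which 3 of the 3 values shown sit, and the step that the limit leaves unreadable from compound 1 to compound 4 is expected to stay within the scatter. Compound 4 is therefore estimated at 4000 nM, with a range from 1000 nM to 20000 nM, most likely again only a limit.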

Compound 4, half-maximal inhibitory concentration: > 3200 nM
Compound 4: no number, only a limit; the forecaster's own chance of this, stated with the estimate: 75%; the middle value is on the limit's open side.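

Compound 4, like compound 1, gives only a limit, so no step between compound 1 and compound 4 can be read: the limit of > 3200 nM in this assay, at which 4 of the 4 values shown sit.

The compounds shown leave open whether lengthening the chain at this carbon changes inhibition at all.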